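The source may hold more compounds than are shown below. What is called first, only, known or untested is meant among the compounds shown, and "the series" means these compounds.

Measured compounds:
compound 1 `COc1cc(/C=C/C(=O)/C=C/c2cc(OC)c(OC)c(OC)c2)ccc1OCc1cn(CCOc2cc(=O)oc3ccccc23)nn1` – 820 nM
compound 2 `COc1cc(/C=C/C(=O)/C=C/c2cc(OC)c(OC)c(OC)c2)ccc1OCc1cn(CCCOc2cc(=O)oc3ccccc23)nn1` – 5430 nM

In a functional assay on THP-1 cells (Homo sapiens) for cytotoxicity, read by sulforhodamine B assay, with a stated time of 48 h (a higher number here means a weaker inhibitor, a lower number a stronger inhibitor), compound 1 gives 820 nM, the lower of the two numbers recorded. Its nearest neighbour in this assay is compound 2 `COc1cc(/C=C/C(=O)/C=C/c2cc(OC)c(OC)c(OC)c2)ccc1OCc1cn(CCCOc2cc(=O)oc3ccccc23)nn1`, which gives 5430 nM; the gap between the two values lies beyond the usual scatter, so compound 1 stands as the stronger of the pair. Within the data shown here, no direct one-place step between measured compounds is recorded, so the size of a single change in this assay cannot be read from the data themselves.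

Compound 3 `COc1cc(/C=C/C(=O)/C=C/c2cccs2)ccc1OCc1cn(CCOc2cc(=O)oc3ccccc23)nn1` departs from compound 1 at one place: thiophen-2-yl in place of 3,4,5-trimethoxyphenyl on a double-bonded chain carbon bound to a double-bonded chain carbon. The shared core of compound 1, with its dienone chain and the coumarin-bearing triazole, is kept. Among the measured compounds shown here, with no measured step of comparable kind available, the account can only state an expectation: the number for compound 3 is expected to rise beyond the scatter, with the step of a 3.0-fold higher number from compound 1 to compound 3 (0.48 log units; beyond the scatter) estimated as moderate. Compound 3 is therefore estimated at 2500 nM, within a range of 900 nM to 7000 nM.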

Compound 3, half-maximal inhibitory concentration: 7140 nM
Compound 3: the middle estimate sits 2.9-fold (0.46 log units) below what was measured; measured number above the stated range.
By their numbers in this assay, from the lowest: compound 1; then compounds 2 and 3 (each within the scatter of the next).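

In this assay, thiophen-2-yl in place of 3,4,5-trimethoxyphenyl on a double-bonded chain carbon bound to a double-bonded chain carbon gives an 8.7-fold higher number from compound 1 to compound 3 (0.94 log units; beyond the scatter), the first single change whose size can be read here, and it shows that the number at this position depends on the group it carries. The group that leaves has 12 heavy atoms and 3 hydrogen-bond acceptors, while the group that enters has 5 heavy atoms and 1 hydrogen-bond acceptor, so ring type, size and acceptor count all change in this one step and it cannot separate them. No measurement is at hand that bears on why the number rises.

As far as these compounds go, it remains open whether the rise follows the loss of the methoxy groups or the arrival of the thiophene ring, a question that an unsubstituted phenyl or a 3,4-dimethoxyphenyl at this place could help to settle. From the compounds shown here alone, it is also open whether a furan-2-yl would behave like thiophen-2-yl, and whether the same change would have a step of similar size on the longer chain of compound 2.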